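Series notes: ester in place of anilide on the core

A few compounds are considered here, and "the series" means these few. Any claim that something is new, unique, unknown or untested is made for them only; others in the source may bear on it.

The shared core of compound 1 `Cc1nn(-c2ncnc3nc[nH]c23)c2c1C(C(=O)Nc1ccccc1)CC(=O)N2` is read in a functional assay on HEK293 cells for agonist activity at G-protein coupled receptor 39 (Homo sapiens), read by scintillation proximity assay and inositol phosphate accumulation, with a stated time of 75 min, in the presence of a further agent that is not named here (a lower number here means that less compound is needed, a higher number that more compound is needed for the effect), where compound 1 gives 10 nM. Compound 2 `Cc1nn(-c2ncnc3nc[nH]c23)c2c1C(OCc1ccccc1F)CC(=O)N2` gives 4 nM and compound 3 `Cc1nn(-c2ncnc3nc[nH]c23)c2c1C(OCCn1nccc1C)CC(=O)N2` gives 10 nM. Compound 1 stands level with compound 3 at the digits shown, the two together at the high end of the three numbers; its furthest neighbour is compound 2, with a 2.5-fold lower number from compound 1 to compound 2 (0.40 log units; beyond the scatter). Compound 3 sits at no change at the digits printed from compound 1 to compound 3 (within the scatter), and between the two ethers a 2.5-fold higher number from compound 2 to compound 3 (0.40 log units; beyond the scatter).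

Compound 4 `Cc1nn(-c2ncnc3nc[nH]c23)c2c1C(OC(=O)c1ccc(F)cc1)CC(=O)N2` is not yet measured. Its change from compound 1 is ((4-fluorophenyl)carbonyl)oxy in place of phenylcarbamoyl on a saturated ring carbon. Within the data shown here, the steps that bear on it are the two from compound 1, both of which swap the phenylcarbamoyl group for an oxygen-linked substituent: one within the scatter, one modest beyond it. Among the measured compounds shown here, the new group keeps a carbonyl, unlike either ether, so no measured step matches it closely. The expectation is a small step, a 1.4-fold lower number from compound 1 to compound 4 (0.15 log units; within the scatter), at most modest. For compound 4 the estimate is 7 nM, with a range from 2.5 nM to 25 nM.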

Compound 4, half-maximal effective concentration: 4 nM
Compound 4: the middle estimate sits 1.8-fold (0.24 log units) above what was measured; low and high end bracket the measured number.
By their numbers in this assay, from the lowest: compounds 2 and 4 (each within the scatter of the next); then compounds 1 and 3 (each within the scatter of the next).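

In this assay an ester on the saturated ring carbon reads as well as the 2-fluorobenzyl ether, with a 2.5-fold lower number from compound 1 to compound 4 (0.40 log units; beyond the scatter) against the anilide and no change at the digits printed from compound 2 to compound 4 (within the scatter) against that ether. A carbonyl in the oxygen-linked group thus makes no difference visible here, and a number at this level does not require the hydrogen-bond donor of phenylcarbamoyl. Among the oxygen-linked groups there is a 2.5-fold lower number from compound 3 to compound 4 (0.40 log units; beyond the scatter) with the fluorinated benzene ring, so compounds 2 and 4 both sit lower than compound 3, though compound 1, which carries no fluorine, stands level with compound 3 and the fluorine and the linker change together in these steps.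

Going by these compounds, whether the fluorine or the oxygen link carries the step away from phenylcarbamoyl stays open, as does how an unsubstituted benzoyloxy group, an amine or a longer chain would read on this ring carbon. Nothing shown gives a reason for any of these steps.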